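A few compounds are considered here, and "the series" means these few. Any claim that something is new, unique, unknown or untested is made for them only; others in the source may bear on it.

Compound 1 `OC[C@H]1O[C@@H](n2cnc3c(NCc4ccccc4Br)ncnc32)[C@H](O)[C@@H]1O` gives 12300 nM in a functional assay on CCRF-CEM cells (Homo sapiens) for antiproliferative activity, with a stated time of 72 h; on this read-out lower numbers stand for stronger inhibition and higher numbers for weaker inhibition.
Compound 2 `OC[C@H]1O[C@@H](n2cnc3c(NCc4ccc(Cl)c(Cl)c4)ncnc32)[C@H](O)[C@@H]1O` gives 3800 nM in this assay.

Among the measured compounds shown here, compound 1 stands highest of the two numbers measured so far; its nearest neighbour is compound 2, reached by a 3.2-fold lower number from compound 1 to compound 2 (0.51 log units; beyond the scatter). Compound 3 `OC[C@H]1O[C@@H](n2cnc3c(NCc4ccc(F)c(F)c4F)ncnc32)[C@H](O)[C@@H]1O` has not yet been measured. It differs from compound 1 in one place: 2,3,4-trifluorophenyl in place of 2-bromophenyl on a saturated chain carbon bound to a nitrogen on an aromatic ring. For the measured compounds named here, the only measured step that bears on this change is the one in which 3,4-dichlorophenyl replaced 2-bromophenyl on the same saturated chain carbon, which gave a 3.2-fold lower number from compound 1 to compound 2 (0.51 log units; beyond the scatter), a modest but real lowering. Exchanging 2-bromophenyl for 2,3,4-trifluorophenyl is a different swap, so the direction remains uncertain; a small lowering is expected for compound 3, by a 1.5-fold lower number from compound 1 to compound 3 (0.19 log units; within the scatter). Compound 3 is therefore expected to give about 8000 nM in this assay, within a range of 3000 nM to 20000 nM.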

Compound 3, half-maximal inhibitory concentration: 58200 nM
For compound 3 the middle estimate is 7.3-fold (0.86 log units) below the measured one, and the stated range ends below it.
By their numbers in this assay, from the lowest: compound 2; then compound 1; then compound 3.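

The same position that allowed a lowering with 3,4-dichlorophenyl also allows a clear loss: in this assay, 2,3,4-trifluorophenyl in place of 2-bromophenyl gives a 4.7-fold higher number from compound 1 to compound 3 (0.68 log units; beyond the scatter) and stands against 3,4-dichlorophenyl at a 15-fold higher number from compound 2 to compound 3 (1.19 log units; beyond the scatter) on this read-out. Compound 3 is thus the weakest of the three, so the halogen pattern on this phenyl ring matters a great deal, and carrying more halogen atoms does not by itself lower the number. Nothing available explains why this ring fares worse.

As far as these compounds go, it remains open whether the rise follows from having fluorine as the halogen or from the places the halogens occupy on the ring. Also open, from the compounds shown here alone, is how a methoxy group, an amine or a longer chain carrying the phenyl ring would behave at this position.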